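Halogenated anilines on a shared imidazopyrazine-type core

The source may report more compounds than this note shows. Statements on the series, on what has been measured and on what is new or still open speak of the compounds shown alone.

Measured compounds:
compound 1 `Cc1n[nH]c2ccc(-c3nc4cnc(N5CCN(C)CC5)cn4c3Nc3ccc(F)cc3)cc12` — 32300 nM
compound 2 `Cc1n[nH]c2ccc(-c3nc4cnc(N5CCN(C)CC5)cn4c3Nc3ccccc3)cc12` — "not determined" (no result reported)

Compound 1 was tested in a functional assay on MV4-11 cells (Homo sapiens) for inhibition, with a stated time of 120 h (on this read-out lower numbers stand for stronger inhibition and higher numbers for weaker inhibition), and gave 32300 nM. Compound 2 has "not determined" (no result reported) in this assay, so it stands nowhere on the scale shown; the only anchor is compound 1. Compound 3 `Cc1n[nH]c2ccc(-c3nc4cnc(N5CCN(C)CC5)cn4c3Nc3ccc(Br)cc3Cl)cc12` carries the change (4-bromo-2-chlorophenyl in place of phenyl on a nitrogen on an aromatic ring). Within the data shown here, with no measured step to lean on, the size and direction of the move from compound 2 to compound 3 in this assay cannot be read from the data. Taking compound 1 as the sole reference, compound 3 is expected to fall near 20000 nM, with a range of 3000 nM to 100000 nM.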

Compound 3, half-maximal inhibitory concentration: 9220 nM
Beside the measured number, compound 3's estimate is 2.2-fold (0.34 log units) above it; low and high end bracket the measured number.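

In this assay the exchange of 4-fluorophenyl for 4-bromo-2-chlorophenyl on the nitrogen on an aromatic ring gives a 3.5-fold lower number from compound 1 to compound 3 (0.54 log units; beyond the scatter), so the number at this position does shift with the halogens on the ring. The compounds offer no explanation for this modest step. With no number for compound 2, steps from the unsubstituted anilino compound cannot be read. Going by these compounds, whether the bromine, the chlorine or the two together account for the shift stays open, as does how a ring bearing an amine or a carboxylic acid would read out.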